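Pyridin-4-yl to pyridin-3-yl: working notes on the series

This account rests on a few compounds, and the source may have more. Where it says the series, first, only, none or still open, it means among the compounds named here.

- compound 1 `O=C(CCCCCC(=O)Nc1nnc(-c2cccnc2)s1)NO` gives > 60000 nM as a limit, not a number
- compound 2 `O=C(CCCCCCC(=O)Nc1nnc(-c2ccncc2)s1)NO` gives 4150 nM as a measured number

Among the compounds with values here, in a functional assay on K562 cells (Homo sapiens) for antiproliferative activity, read by MTT assay, with a stated time of 48 h (a lower number here means a stronger inhibitor, a higher number a weaker inhibitor), compound 2 gives 4150 nM as the only measured number so far. Within the data shown here, the sole other result is the one for compound 1 at > 60000 nM and it is a limit of this assay only.

Compound 3 `O=C(CCCCCCC(=O)Nc1nnc(-c2cccnc2)s1)NO` is still unmeasured. It differs from compound 2 in one group, with pyridin-3-yl in place of pyridin-4-yl on an aromatic carbon and the atoms otherwise unchanged. Among the measured compounds shown here, no measured pair isolates this change, so its size in this assay can only be judged cautiously. The expectation rests on compound 2 at 4150 nM as the one available anchor. A small step is expected, close to the scatter, and any drift towards weaker inhibition would be slight. The estimated move is a 1.2-fold higher number from compound 2 to compound 3 (0.08 log units; within the scatter) and no large shift is foreseen. The estimate for compound 3 is 5000 nM with an expected range from 1500 nM to 17000 nM in this series.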

Compound 3, half-maximal inhibitory concentration: 4360 nM
Compound 3: middle estimate off by 1.1-fold (0.06 log units), on the high side; low and high end bracket the measured number.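

In this assay, pyridin-3-yl in place of pyridin-4-yl on the aromatic carbon gives a 1.1-fold higher number from compound 2 to compound 3 (0.02 log units; within the scatter), so the two pyridinyl groups cannot be told apart at this place with the longer chain in compound 2 and compound 3. Within the data shown here, with pyridin-3-yl held fixed, the chain change gives an at least 13-fold lower number from compound 1 to compound 3 (1.13 log units; beyond the scatter), which places the only large step in this set on the chain and not on the pyridinyl attachment. Compound 1 stands at a limit and not at a number: the limit of > 60000 nM in this assay, at which 1 of the 3 values shown sits.

Going by these compounds, it remains open whether a still longer chain between the hydroxycarbamoyl group and the amide would move the number further in this assay. On these data alone, it is equally open whether phenyl or pyridin-2-yl on the same aromatic carbon would stay within the scatter of compound 3.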